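The source may report more compounds than this note shows. Statements on the series, on what has been measured and on what is new or still open speak of the compounds shown alone.

The measured compounds:

Compound 1, `Fc1cccc(F)c1Cc1cnc(Nc2ccc(-c3ccncc3)c(Cl)c2)o1`: in an ADME assay on MT2 cells (Homo sapiens) for cytotoxicity, read by MTT assay (on this read-out lower numbers stand for higher toxicity in this test and higher numbers for lower toxicity in this test), compound 1 gives 9300 nM.
Compound 2, `O=c1ncccn1SCCc1ccc(Nc2ncc(Cc3c(F)cccc3F)o2)cc1`: in this assay compound 2 gives only the limit > 100000 nM.
Compound 3, `Fc1cccc(F)c1Cc1cnc(Nc2ccc(COc3ccncc3)cc2)o1`: in this assay compound 3 likewise gives only the limit > 100000 nM.

Compound 1 thus stands as the one compound with a number; the other two values are limits, as shown by the limit of > 100000 nM in this assay, at which 2 of the 3 values shown sit. Among the measured compounds shown here, the single step between measured compounds that differ in one place, a step that the two limits leave unreadable from compound 2 to compound 3, runs from one limit to another and its size cannot be read.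

Compound 4, `OCc1ccc(Nc2ncc(Cc3c(F)cccc3F)o2)cc1Cl`, differs from compound 1 by hydroxymethyl in place of pyridin-4-yl on an aromatic carbon. For the measured compounds named here, no measured step covers this change, so the expectation rests on compound 1 alone and on the fact that two of three compounds sit at the limit. The writer expects a step of a 3.2-fold higher number from compound 1 to compound 4 (0.51 log units; beyond the scatter) from compound 1 toward lower toxicity, with wide uncertainty. For compound 4 the estimate is 30000 nM, within a range from 6000 nM to 150000 nM, and a limit is a real possibility.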

Compound 4, half-maximal cytotoxic concentration: 90000 nM
The estimate for compound 4 lay 3.0-fold (0.48 log units) below the measured number; the measured number falls inside the stated range.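

In this assay, among the compounds shown here, the aromatic carbon ortho to the chloro group gives the first step that can be read, a 9.7-fold higher number from compound 1 to compound 4 (0.99 log units; beyond the scatter). With the chloro group kept in place, hydroxymethyl in place of pyridin-4-yl therefore moves the number toward lower toxicity in this test, so this position does influence the read-out. Compound 2 and compound 3 give only limits and cannot be placed against that step, and the series has little readable range left above compound 4: the limit of > 100000 nM in this assay, at which 2 of the 4 values shown sit.

As far as these compounds go, what a methyl group, an aminomethyl group or a carboxylic acid would give on this carbon stays open. Also open, from the compounds shown here alone, is whether phenyl or pyridin-3-yl in place of pyridin-4-yl would keep the number of compound 1, and what the chloro group contributes on its own.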